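The compounds below may be only part of what the source reports. "The series", "measured", "known", "first", "only" and "open" are said of these compounds alone.

Measured compounds:
compound 1, `CC(C)(C)c1ccc(CNCCCNS(=O)(=O)c2cc(C(F)(F)F)cc(C(F)(F)F)c2)cc1`, 2500 nM in a functional assay on NCI-H460 cells (Homo sapiens) for inhibition, read by MTT assay, with a stated time of 72 h; a higher number here means a weaker inhibitor of growth, a lower number a stronger inhibitor of growth
compound 2, `O=S(=O)(NCCNCc1ccc(-c2ccccc2)cc1)c1cc(C(F)(F)F)cc(C(F)(F)F)c1`, 2600 nM in this assay
compound 3, `O=S(=O)(NCCCNCc1ccc(Br)cc1)c1cc(C(F)(F)F)cc(C(F)(F)F)c1`, 2500 nM in this assay

Compound 2 gives the highest of the three numbers in this assay, but its nearest neighbour, compound 1, and its furthest, compound 3, both lie within the scatter of it, so no order among the three can be read. The step to compound 4, `CC(C)(C)c1ccc(CNCCNS(=O)(=O)c2cc(C(F)(F)F)cc(C(F)(F)F)c2)cc1`, is tert-butyl in place of phenyl on an aromatic carbon. Within the data shown here, one measured step bears on this kind of exchange on that ring: no change at the digits printed from compound 1 to compound 3 (within the scatter), which shows that swapping the group on the aromatic carbon left the number where it was. The tert-butyl of compound 4 is also carried by compound 1, which gives 2500 nM in this assay, and compound 2 with the phenyl gives 2600 nM; the two values show no separation. The expected step from compound 2 to compound 4 is therefore none beyond the scatter, a 1.0-fold lower number from compound 2 to compound 4 (0.02 log units; within the scatter). For compound 4 in this assay the estimate is 2500 nM, with a range from 1200 nM to 5200 nM.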

Compound 4, concentration for 50% growth inhibition: 14000 nM
Compound 4: the middle estimate sits 5.6-fold (0.75 log units) below what was measured, and the stated range ends below it.
By their numbers in this assay, from the lowest: compounds 1, 3 and 2 (each within the scatter of the next); then compound 4.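

In this assay, tert-butyl in place of phenyl on this aromatic carbon, para to a large group, is not a neutral exchange on the shorter chain: it gives a 5.4-fold higher number from compound 2 to compound 4 (0.73 log units; beyond the scatter). The earlier flat result, no change at the digits printed from compound 1 to compound 3 (within the scatter), came from the longer chain and does not carry over to the shorter one. Compound 1, with tert-butyl on the longer chain, gives 2500 nM, and compound 4, with tert-butyl on the shorter chain, gives 14000 nM, so the same group is tied to different numbers on the two chains.

No measurement shown explains this difference. On these data alone, it remains open how bromo behaves on the shorter chain, and whether an amine or a carboxylic acid on that aromatic carbon would keep the number of compound 2 or follow that of compound 4.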